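The source may report more compounds than this note shows. Statements on the series, on what has been measured and on what is new or still open speak of the compounds shown alone.

Measured compounds:
- compound 1 `CC(=O)/C=C1\C(=O)Nc2ccc(Cl)cc21` — 460 nM
- compound 2 `O=C1Nc2ccccc2/C1=N/Nc1ccc(Cl)cc1` — 420 nM

In an assay on MDA-MB-231 cells for inhibition of Indoleamine 2,3-dioxygenase 1 (Homo sapiens), read by spectrophotometry, with stated times of 4 h and 5 h (a lower number here means that less compound is needed, a higher number that more compound is needed for the effect), compound 1 gives 460 nM, and in this assay compound 2 gives 420 nM. Compound 1 has the higher of the two numbers, but the gap to compound 2 is within the scatter, so the two compounds cannot be told apart on these data.

Compound 3 `CC(=O)CC(=O)/C=C1\C(=O)Nc2ccc(Cl)cc21` is yet to be measured in this assay. It differs from compound 1 in one place: acetyl in place of hydrogen on a saturated chain carbon bound to a carbonyl carbon. For the measured compounds named here, no step between two measured compounds of this kind is available, so there is nothing to set the expected size of this change against; the two measured compounds share the same chlorine-bearing core but differ in the whole side chain, not in this acetyl.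

Going by the values given here, with no comparable step in hand, the account expects the step from compound 1 to compound 3 in this assay to be small, a 1.3-fold higher number from compound 1 to compound 3 (0.12 log units; within the scatter), probably not beyond the scatter, with a slight lean toward a higher number. Compound 3 is accordingly estimated at 600 nM in this assay, with a range from 200 nM to 2000 nM.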

Compound 3, half-maximal effective concentration: 330 nM
Compound 3: middle estimate off by 1.8-fold (0.26 log units), on the high side, within the range that was stated.
By their numbers in this assay, from the lowest: compounds 3, 2 and 1 (each within the scatter of the next).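

In this assay, acetyl in place of hydrogen on a saturated chain carbon bound to a carbonyl carbon gives a 1.4-fold lower number from compound 1 to compound 3 (0.14 log units; within the scatter), a step within the scatter, so this change cannot be told apart from no change at all. For the compounds shown here, this is the first direct reading at this place: compounds 1 and 2 differ in the whole side chain and could say nothing about one added group, whereas compound 3 shows that the side chain of compound 1 can carry the acetyl, with its added heavy atoms and its hydrogen-bond acceptor, and keep a number in the same range. Nothing at hand bears on why the number holds at this place.

The compounds shown leave open whether this holds only for acetyl or also for other groups on the same carbon, such as an amine, a carboxylic acid or a longer chain. Going by these compounds alone, they also leave open whether acetyl would behave the same way on a side chain other than that of compound 1, since this is the only step of its kind so far.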